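The compounds below may be only part of what the source reports. "The series", "measured", "known", "first", "only" and "open" are said of these compounds alone.

Working notes on the series. Of the compounds shown here, two of this set have been measured in an ADME assay on the whole organism (plasma) for pharmacokinetics, with Rattus norvegicus as the target, at a dose of 10 mg/kg by the oral route; a higher number here means more compound in the circulation at the dose given, a lower number less compound in the circulation. Compound 1 `O=C(O)c1cc(-c2cccc(COc3ccc4c(c3)CN(C3CCCC3)C4=O)c2)ccc1O` gives 3150000 ng.h/mL in this assay, the lower of the two numbers at hand. Compound 2 `O=C(O)c1cc(-c2cccc(COc3ccc4c(=O)n(C5CC5)sc4c3)c2)ccc1Cl` gives 27800000 ng.h/mL in this assay, a higher number than compound 1 by a margin beyond the usual scatter. Compound 2 differs from compound 1 in several places at once, so its two values are all that can be said of that pair.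

Compound 3 `COc1ccc(C(=O)O)cc1-c1cccc(COc2ccc3c(c2)CN(C2CCCC2)C3=O)c1` has not yet been measured. It differs from compound 1 by one change: 5-carboxy-2-methoxyphenyl in place of 3-carboxy-4-hydroxyphenyl on an aromatic carbon. For the measured compounds named here, no measured pair shows this change, so its effect in this assay is unknown. The expected step from compound 1 to compound 3 is small and upward, a 1.4-fold higher number from compound 1 to compound 3 (0.15 log units; within the scatter), and may well fall within the scatter. Compound 3 is accordingly estimated at 4500000 ng.h/mL in this assay, with a range from 1500000 ng.h/mL to 13000000 ng.h/mL.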

Compound 3, area under the concentration-time curve: 5490 ng.h/mL
Compound 3: the middle estimate sits 820-fold (2.91 log units) above what was measured, and the stated range ends above it.
By their numbers in this assay, from the lowest: compound 3; then compound 1; then compound 2.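

In this assay, for the compounds shown here, 5-carboxy-2-methoxyphenyl in place of 3-carboxy-4-hydroxyphenyl gives a 570-fold lower number from compound 1 to compound 3 (2.76 log units; beyond the scatter), the first step that can be read at a single place, and it shows that this aromatic carbon is far from indifferent to what it carries. The counted difference is small, the group that enters having slightly more heavy atoms and slightly fewer hydrogen-bond donors than the group that leaves, with the carboxy group kept, yet the step is large. Nothing at hand bears on the origin of this step.

One pair does not separate the methyl on the oxygen from the different place of that oxygen on the ring. On these data alone, how 5-carboxy-2-hydroxyphenyl or 3-carboxy-4-methoxyphenyl would read here stays open, as does an amine in place of the carboxylic acid.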